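The source may report more compounds than this note shows. Statements on the series, on what has been measured and on what is new or still open speak of the compounds shown alone.

Among the compounds with values here, in a functional assay on SR cells (Homo sapiens) for inhibition, read by sulforhodamine B assay, with a stated time of 48 h, tested at 10 uM (a lower number here means less inhibition of growth, a higher number more inhibition of growth at the concentration tested), compound 2 `COc1ccc(-c2nc3sc(-c4ccccc4)cn3n2)cc1` stands highest of the three compounds measured so far, with a reading of 58% in this test. In this assay compound 1 `CC(=O)c1ccc(NC(=O)Cn2nc(-c3ccc(Cl)cc3)nc2N)cc1` gives 7.32% and compound 3 `C/C(=N/O)c1ccc(NC(=O)Cn2nc(-c3ccccc3)nc2N)cc1` gives 5.58% on the same scale. Both lie lower than compound 2 by gaps beyond the usual scatter, while the two of them sit within scatter of each other. Within the data shown here, compounds 1 and 3 are built differently from compound 2, and no two measured compounds differ in only one place, so no measured step shows what a single change does here.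

Compound 4 `COc1ccc(-c2nc3sc(-c4ccc(Cl)cc4)cn3n2)cc1` keeps the core of compound 2 and makes one change (chloro in place of hydrogen on an aromatic carbon): chloro in place of hydrogen on an aromatic carbon, para to a large group, which turns phenyl into 4-chlorophenyl. Among the measured compounds shown here, the only close reference is compound 2 (58%), and the data give no firm direction for this replacement. A small rise is therefore only a weak guess. Expected here is a number 4 percentage points higher from compound 2 to compound 4 (within the scatter) and no clear move beyond the scatter. In this assay the estimated reading for compound 4 is 62% within an expected range of 38% to 85% (an expectation, not a measurement).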

Compound 4, percent growth inhibition at one concentration: 48.9%
Beside the measured number, compound 4's estimate is 13.1 percentage points above it; the range from low to high includes it.
By their numbers in this assay, from the lowest: compounds 3 and 1 (each within the scatter of the next); then compounds 4 and 2 (each within the scatter of the next).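

In this assay, within the data shown here, chloro in place of hydrogen on an aromatic carbon, para to a large group, which turns phenyl into 4-chlorophenyl, gives a number 9.1 percentage points lower from compound 2 to compound 4 (within the scatter), and this is the only measured step that isolates a single change. It shows that, at the one concentration tested, this position can carry a chlorine atom without a shift that can be told apart from the ordinary spread of repeated measurements, so the step cannot be read as either a gain or a loss of growth inhibition. Nothing measured here speaks to the reason for this outcome.

As far as these compounds go, with a single replacement at a single position, it remains open whether a different group in the same place, such as an amine, a carboxylic acid or a longer alkyl chain, would move the reading beyond the scatter. From the compounds shown here alone, it also remains open whether chloro would have a similar effect on another carbon of this ring or on the ring that carries the methoxy group.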